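This account rests on a few compounds, and the source may have more. Where it says the series, first, only, none or still open, it means among the compounds named here.

Compound 1 `CN(C)CCCOc1ccc(CN2CC[C@H](NC(=O)c3ccccc3)C2)cc1` — 2510 nM
Compound 2 `CC(C)C[C@H](NC(=O)c1cc2ccccc2o1)C(=O)N[C@H]1CCN(Cc2ccc(OCCCN(C)C)cc2)C1` — 158 nM
Compound 3 `CC(C)C[C@H](NC(=O)c1cc2ccccc2[nH]1)C(=O)N[C@H]1CCN(Cc2ccc(OCCCN(C)C)cc2)C1` — 501 nM

In an assay on HEK293 cells for binding affinity to Urotensin-2 receptor (Homo sapiens), read by radioligand binding (a higher number here means a weaker inhibitor, a lower number a stronger inhibitor), compound 3 holds the second highest of the three numbers; compound 2 lies nearer, compound 1 further away. The next compound, compound 4 `CC(=O)N[C@@H](CC(C)C)C(=O)N[C@H]1CCN(Cc2ccc(OCCCN(C)C)cc2)C1`, differs from compound 3 in one place: methyl in place of 1H-indol-2-yl on a carbonyl carbon. For the measured compounds named here, only one measured step touches this position, a 3.2-fold higher number from compound 2 to compound 3 (0.50 log units; beyond the scatter), and it swaps one bicyclic aromatic ring for another; no measured pair removes the ring system entirely, so the new step is expected to be judged without a close precedent. Since both rings gave the lower numbers here, compound 4 is expected to land well beyond the scatter in the weaker direction, a 10-fold higher number from compound 3 to compound 4 (1.00 log units; beyond the scatter), with an estimate for compound 4 of 5000 nM, ranging from 1500 nM to 20000 nM.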

Compound 4, inhibition constant: 2510 nM
Compound 4: middle estimate off by 2.0-fold (0.30 log units), on the high side; low and high end bracket the measured number.
By their numbers in this assay, from the lowest: compound 2; then compound 3; then compounds 1 and 4 (each within the scatter of the next).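

In this assay the aromatic groups on this carbonyl carbon clearly matter: methyl in place of them gives a 5.0-fold higher number from compound 3 to compound 4 (0.70 log units; beyond the scatter) and the larger 16-fold higher number from compound 2 to compound 4 (1.20 log units; beyond the scatter). The 1-acetamido-3-methylbutyl group with its acetyl end offers no gain over phenyl, with no change at the digits printed from compound 1 to compound 4 (within the scatter), so that side chain pays off only alongside an aromatic group. Nothing available explains these shifts. The compounds shown leave open whether a single ring such as pyridyl or cyclohexyl, or a longer chain such as butyl, in place of methyl would restore the affinity of compound 2 .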